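This account rests on a few compounds, and the source may have more. Where it says the series, first, only, none or still open, it means among the compounds named here.

Measured so far in a functional assay on PC-3 cells (Homo sapiens) for inhibition, read by MTT assay, with a stated time of 72 h; a lower number here means a stronger inhibitor, a higher number a weaker inhibitor:
- compound 1 `C#CCSc1nc(NCCC#N)c2ccncc2n1`: > 80000 nM, a limit of the assay
- compound 2 `C#CCSc1nc(Nc2ccccc2Cl)c2ccncc2n1`: > 80000 nM, likewise a limit
- compound 3 `C#CCSc1nc(Nc2ccc(Cl)cc2)c2ccncc2n1`: 19000 nM

Compound 1 thus stands only at a limit in this assay, and so does compound 2 (the limit of > 80000 nM in this assay, at which 2 of the 3 values shown sit). Compound 4 `C#CCSc1nc(Nc2cccc(Cl)c2)c2ccncc2n1` is not yet measured; it differs from compound 1 by 3-chlorophenyl in place of 2-cyanoethyl on a nitrogen on an aromatic ring. Among the measured compounds shown here, the steps that bear on this are an at least 4.2-fold lower number from compound 1 to compound 3 (0.62 log units; beyond the scatter) and an at least 4.2-fold lower number from compound 2 to compound 3 (0.62 log units; beyond the scatter), both pointing the same way, whereas a step that the two limits leave unreadable from compound 1 to compound 2 is unreadable. For the measured compounds named here, a 3-chlorophenyl has no measured counterpart, so the expected step of an at least 2.2-fold lower number from compound 1 to compound 4 (0.35 log units; beyond the scatter) is taken as a lowered number, likely smaller than that seen with 4-chlorophenyl. Compound 4 is therefore estimated at 35000 nM, with a range from 12000 nM to 80000 nM.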

Compound 4, half-maximal inhibitory concentration: 56500 nM
For compound 4 the middle estimate is 1.6-fold (0.21 log units) below the measured one, and the stated range covers the measured number.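

In this assay, 3-chlorophenyl in place of 4-chlorophenyl on this nitrogen gives a 3.0-fold higher number from compound 3 to compound 4 (0.47 log units; beyond the scatter), so the place of the chlorine on the phenyl ring changes the reading even where compound 3 and compound 4 share everything else. The steps to the other two compounds are only floors within the scatter: an at least 1.4-fold lower number from compound 1 to compound 4 (0.15 log units; that floor lies within the scatter) and an at least 1.4-fold lower number from compound 2 to compound 4 (0.15 log units; that floor lies within the scatter). Both floors rest on a limit: the limit of > 80000 nM in this assay, at which 2 of the 4 values shown sit.

Going by these compounds, how far compound 2 truly lies from compound 4 stays open. So does whether a bromophenyl, a methoxyphenyl or a benzyl on this nitrogen would give a lower number than 4-chlorophenyl.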